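Fluoro to trifluoromethyl in a small cytotoxicity series

The source may report more compounds than this note shows. Statements on the series, on what has been measured and on what is new or still open speak of the compounds shown alone.

Compound 1 `FC(F)(F)c1ccc(-c2nn(-c3ccccc3)cc2-c2nc3ccccc3[nH]2)cc1` gives 167000 nM
Compound 2 `Cc1ccc(-c2nn(-c3ccccc3)cc2-c2nc3ccccc3n2S(=O)(=O)c2ccccc2)cc1` gives 138000 nM
Compound 3 `O=S(=O)(c1ccccc1)n1c(-c2cn(-c3ccccc3)nc2-c2ccc(F)cc2)nc2ccccc21` gives 96300 nM

The three compounds were all measured in an ADME assay on HEK-293T cells (Homo sapiens) for cytotoxicity, read by MTT assay, with a stated time of 24 h (a lower number here means that less compound is tolerated, a higher number that more compound is tolerated), and lie close together. Compound 3 gives 96300 nM and sits within the scatter of both compound 1 and compound 2, so it holds no distinct place among them.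

The next structure is compound 4 `O=S(=O)(c1ccccc1)n1c(-c2cn(-c3ccccc3)nc2-c2ccc(C(F)(F)F)cc2)nc2ccccc21`, which carries trifluoromethyl in place of fluoro on an aromatic carbon, para to a large group (trifluoromethyl in place of fluoro on an aromatic carbon). Among the compounds with values here, the one measured step that bears on this change is a 1.4-fold lower number from compound 2 to compound 3 (0.16 log units; within the scatter), with fluoro in place of methyl on an aromatic carbon, and it stays within the scatter. The trifluoromethyl group of compound 4 also stands on compound 1, which gives 167000 nM, but compound 1 differs elsewhere as well. Within the data shown here, no measured step isolates trifluoromethyl on the core shared by compound 2 and compound 3.

Among the measured compounds shown here, with only that small step as a guide, no change beyond the scatter is expected, and the estimated move is a 1.1-fold higher number from compound 3 to compound 4 (0.04 log units; within the scatter). For compound 4 the expected value is 105000 nM, with an estimated range of 60000 nM to 180000 nM.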

Compound 4, half-maximal cytotoxic concentration: 128000 nM
Beside the measured number, compound 4's estimate is 1.2-fold (0.09 log units) below it; low and high end bracket the measured number.
By their numbers in this assay, from the lowest: compounds 3, 4, 2 and 1 (each within the scatter of the next).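

In this assay, the position on the aromatic carbon para to a large group now has a direct reading for the 4-fluorophenyl to 4-(trifluoromethyl)phenyl change, with a 1.3-fold higher number from compound 3 to compound 4 (0.12 log units; within the scatter), and methyl at that place can be set against trifluoromethyl as well, with a 1.1-fold lower number from compound 2 to compound 4 (0.03 log units; within the scatter). Together with the earlier methyl to fluoro step, these readings show that methyl, fluoro and trifluoromethyl at this position cannot be told apart in this assay on the shared core, even though the entering trifluoromethyl counts four heavy atoms against the single one of fluoro. Within the data shown here, the new compound also gives the first look at the aromatic nitrogen, where phenylsulfonyl stands in place of hydrogen with a 1.3-fold lower number from compound 1 to compound 4 (0.12 log units; within the scatter), so that this larger change also stays inside the scatter, and nothing available offers a reason for any of these readings.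

The compounds shown leave open whether a group of another kind at this position, such as an amine or a carboxylic acid, would move the number beyond the scatter. They also leave open whether a longer chain on the aromatic nitrogen would do so where phenylsulfonyl and hydrogen do not.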